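Moving the ring oxygen: oxan-3-yl to oxan-4-yl

The source may hold more compounds than are shown below. What is called first, only, known or untested is meant among the compounds shown, and "the series" means these compounds.

Measured so far in a physicochemical assay for lipophilicity, read by HPLC, with a stated time of 90 min, tested at 100 uM; on this read-out lower numbers stand for lower lipophilicity and higher numbers for higher lipophilicity:
compound 1 `O=C(Nc1ccc(C(F)(F)F)cc1)NC1CCN(C(=O)C2CCCOC2)CC1` gives 3.41
compound 2 `O=C(Nc1ccc(OC(F)(F)F)cc1)NC1CCN(C(=O)C2CCOC2)CC1` gives 3.22
compound 3 `O=C(Nc1ccc(C(F)(F)F)c(F)c1)NC1CCN(C(=O)C2CCCOC2)CC1` gives 3.84

Among these three, compound 1 sits below compound 3, with a number 0.43 log units higher from compound 1 to compound 3 (beyond the scatter), while the value of compound 2 lies within the scatter of that of compound 1. Compound 4 `O=C(Nc1ccc(C(F)(F)F)cc1)NC1CCN(C(=O)C2CCOCC2)CC1` is not yet measured. It differs from compound 1 only as counted here: oxan-4-yl in place of oxan-3-yl on a carbonyl carbon. Among the measured compounds shown here, the one measured step, from compound 1 to compound 3, concerns fluoro on the aromatic ring, not the oxanyl, so no measured step bears directly on this change. As the two groups share the same atoms and count of acceptors, no step beyond the scatter is expected in this assay: compound 4 is estimated at 3.38, between 3.08 and 3.68, an expected step of a number 0.03 log units lower from compound 1 to compound 4 (within the scatter).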

Compound 4, partition coefficient: 3.16
For compound 4 the middle estimate is 0.22 log units above the measured one; the range from low to high includes it.
By their numbers in this assay, from the lowest: compounds 4, 2 and 1 (each within the scatter of the next); then compound 3.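

Among the compounds shown here, compound 4 gives the first reading of a change on the carbonyl carbon in this assay, since the only earlier step concerned fluoro on the aromatic ring. Swapping oxan-3-yl for oxan-4-yl there, with the heavy atoms and acceptor count unchanged, gives a number 0.25 log units lower from compound 1 to compound 4 (within the scatter) and so does not separate the two groups. Nothing at hand explains the size of this step.

Still open, as far as these compounds go, is whether a piperidin-4-yl amine or a carboxylic acid on the carbonyl carbon would stay as close to compound 1.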